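The source may hold more compounds than are shown below. What is called first, only, known or untested is meant among the compounds shown, and "the series" means these compounds.

Three compounds stand measured in an assay on CHO cells for displacement of a labelled ligand from adenosine receptor A1 (Homo sapiens), read by scintillation counting, with a stated time of 60 min, tested at 10 uM; on this read-out lower numbers stand for less inhibition and higher numbers for more inhibition at the one concentration tested (going by the name of the read-out). Compound 1 `N=c1oc2ccc(Br)cc2cc1C(=O)NC1CCCCC1` gives 5% in this assay. Compound 2 `COc1cccc2cc(C(=O)NCC(=O)O)c(=O)oc12` gives 27% in this assay, and compound 3 `O=C(NCC(O)CO)c1cc2cc(Cl)ccc2oc1=O` gives 21% in this assay. Among the three, the number of compound 2 lies above that of compound 1 by a gap beyond the scatter, while the number of compound 3 sits within the scatter of it, so no order can be read between compound 2 and compound 3.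

Compound 4 `O=C(O)CNC(=O)c1cc2ccccc2oc1=O` has not yet been measured in this assay. It differs from compound 2 in one place: hydrogen in place of methoxy on an aromatic carbon. Among the measured compounds shown here, no pair of measured compounds differing in just one place is available, so the size of such a step is not known from the numbers at hand.

Since the three measured numbers all remain low and cluster at the lower end of the read-out, the removal of the methoxy is expected to shift the inhibition only slightly, if at all, and the step from compound 2 to compound 4 is estimated to be a small decrease of a number 7 percentage points lower from compound 2 to compound 4 (within the scatter), within the scatter. Compound 4 is therefore expected to show about 20% in this assay, within a range from 5% to 38%.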

Compound 4, a percentage reported as inhibition, at one concentration (the size of the read-out at that concentration, not a potency): 1%
Beside the measured number, compound 4's estimate is 19 percentage points above it; the measured number lies below the stated range.
By their numbers in this assay, from the lowest: compounds 4 and 1 (each within the scatter of the next); then compounds 3 and 2 (each within the scatter of the next).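

In this assay, among the compounds shown here, the change gives the first step that can be read between two compounds differing in one place, and it runs a number 26 percentage points lower from compound 2 to compound 4 (beyond the scatter) when hydrogen stands in place of methoxy. For the compounds shown here, the position, on an aromatic carbon ortho to a fused ring and meta to a fused ring, therefore matters to this read-out, at least in this pair, which the earlier compounds could not show because none of them formed such a pair. The numbers give the size of this step but no reason for it.

The step rests on a single pair that shares one amide side chain ending in a carboxylic acid, so the compounds shown leave open whether methoxy would count for as much beside the cyclohexyl amide of compound 1 or the dihydroxypropyl amide of compound 3. They also leave open whether an ethoxy, a hydroxyl or an amine on this same aromatic carbon would keep, raise or lower the number, and whether methoxy at another place on the ring would do the same.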